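This account rests on a few compounds, and the source may have more. Where it says the series, first, only, none or still open, it means among the compounds named here.

Compound 1 `O=C(Nc1ccccc1Br)N[C@@H]1CCN(c2ccc(Br)cn2)C1` and compound 2 `Cc1cccc2c1CCN2CCNC(=O)Nc1ccccc1Br` share the same urea core and have both been tested in a functional assay for antagonist activity at transient receptor potential cation channel subfamily V member 1 (Rattus norvegicus), read by FLIPR; on this read-out higher numbers stand for higher potency (the scale is a negative logarithm) and lower numbers for lower potency. In this assay, going by the values given here, compound 1 gives 7.2, and compound 2 gives 7.4; these two values sit within the usual scatter of each other, so compound 1 stands level with the only other number known here rather than apart from it. Compound 3 `Cc1ccc(N2CC[C@@H](NC(=O)Nc3ccccc3Br)C2)nc1` has not yet been tested. It differs from compound 1 in one place: methyl in place of bromo on an aromatic carbon. Among the compounds with values here, no pair of measured compounds shows this same change, so its size cannot be read off directly. Trading one small group for another on the same aromatic carbon is expected to shift potency little, at most slightly downward and hardly beyond the scatter. The step from compound 1 to compound 3 is expected to read a number 0.20 log units lower from compound 1 to compound 3 (within the scatter). Compound 3 is therefore estimated at 7, with a likely range from 6.3 to 7.6.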

Compound 3, negative logarithm of the antagonist equilibrium constant: < 6.7
Compound 3: no number, only a limit; the forecaster's own chance of this, stated with the estimate: 5%; at least 0.30 log units between middle value and limit.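

In this assay, methyl in place of bromo on this aromatic carbon gives a number at least 0.50 log units lower from compound 1 to compound 3 (beyond the scatter). Going by these compounds alone, this is the first sign that the carbon, two atoms from the ring nitrogen, is sensitive to which group it carries, even though bromo and methyl match in heavy-atom count, hydrogen-bond donors and acceptors, and net charge. The reading for compound 3 is a limit of the assay and not a number, so the full size of the step remains unknown: the limit of < 6.7 in this assay, at which 1 of the 3 values shown sits.

Within the data shown here, with only this one pair, it remains open whether the result reflects something particular to bromo or a shortfall particular to methyl. As far as these compounds go, how a chlorine atom, a nitrile, a methoxy group or an amine would read on the same carbon also remains open.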